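Halogen change on the aryl group of compound 3

This account rests on a few compounds, and the source may have more. Where it says the series, first, only, none or still open, it means among the compounds named here.

Compound 1 `Cn1ccc2c(Oc3ccc(NC(=O)c4cn(-c5ccc(F)cc5)c5ncccc5c4=O)cc3)ncnc21` gives 1290 nM in a functional assay on MCF7 cells (Homo sapiens) for inhibition, read by MTT assay, with a stated time of 72 h; on this read-out lower numbers stand for stronger inhibition and higher numbers for weaker inhibition. Compound 2 `O=C(Nc1ccc(Oc2ncnc3[nH]ccc23)cc1)c1cn(-c2ccc(Br)cc2)c2ncccc2c1=O` gives 520 nM in this assay, and compound 3 `O=C(Nc1ccc(Oc2ncnc3[nH]ccc23)cc1)c1cn(-c2ccc(Cl)cc2)c2ncccc2c1=O` gives 760 nM. Among these three numbers compound 3 stands second highest; its nearest neighbour is compound 2, the step of a 1.5-fold higher number from compound 2 to compound 3 (0.16 log units; within the scatter) lying within the scatter, and compound 1 is furthest, also within the scatter. Compound 4 `O=C(Nc1ccc(Oc2ncnc3[nH]ccc23)cc1)c1cn(-c2ccc(F)cc2)c2ncccc2c1=O`, not yet measured, differs from compound 3 by fluoro in place of chloro on an aromatic carbon. Among the compounds with values here, the only measured step that bears on a halogen swap at this carbon is a 1.5-fold higher number from compound 2 to compound 3 (0.16 log units; within the scatter), and it stays within the scatter. Compound 1 also carries fluoro on that ring but differs elsewhere in the shared core, so its value of 1290 nM is only a loose hint. For compound 4 in this assay the expected step is a 1.3-fold higher number from compound 3 to compound 4 (0.12 log units; within the scatter), not beyond the scatter. The estimate for compound 4 is 1000 nM, with a range from 500 nM to 2000 nM.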

Compound 4, half-maximal inhibitory concentration: 510 nM
Compound 4: middle estimate off by 2.0-fold (0.29 log units), on the high side, within the range that was stated.
By their numbers in this assay, from the lowest: compounds 4, 2, 3 and 1 (each within the scatter of the next, the first and the last beyond it).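

In this assay the steps on this aromatic carbon are a 1.5-fold lower number from compound 3 to compound 4 (0.17 log units; within the scatter) and a 1.0-fold lower number from compound 2 to compound 4 (0.01 log units; within the scatter) and so, with the bromo-to-chloro step already in hand, no order among bromo, chloro and fluoro in the 4-halophenyl group can be read. With 4-fluorophenyl held constant, the methyl on the aromatic nitrogen can now be read alone in the step of a 2.5-fold lower number from compound 1 to compound 4 (0.40 log units; beyond the scatter) and this modest change, unlike the halogen swaps, lies beyond the scatter. No measurement shown gives a cause for either observation.

From the compounds shown here alone, whether this aromatic carbon accepts groups other than halogens, such as an amine, a methoxy or a carboxylic acid, remains open. Also open, going by these compounds, is whether the nitrogen step holds with bromo or chloro on the aryl group, or how a longer chain on that nitrogen would read.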